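The compounds below may be only part of what the source reports. "The series", "measured", "known", "first", "only" and "open" are said of these compounds alone.

Of the compounds shown here, three sharing one amide core have been tested in an assay on CHO cells, read by calcium flux; on this read-out higher numbers stand for weaker inhibition and lower numbers for stronger inhibition. Compound 1 `O=C(Nc1ccc(C(F)(F)F)cc1)c1csc(Cc2c(Cl)cccc2Cl)n1` gives 88 nM in this assay. Compound 2 `O=C(Nc1ccc(C(F)(F)F)cc1)c1csc(Oc2c(Cl)cccc2Cl)n1`, which carries 2,6-dichlorophenoxy in place of 2,6-dichlorobenzyl on an aromatic carbon, gives 1280 nM in this assay, and the change is a 15-fold higher number from compound 1 to compound 2 (1.16 log units; beyond the scatter). Compound 3 `O=C(Nc1ccc(C(F)(F)F)cc1)c1csc(Nc2c(Cl)cccc2C(F)(F)F)n1` gives > 4000 nM in this assay, which is not a number but a limit, (the limit of > 4000 nM in this assay, at which 1 of the 3 values shown sits), the edge of what this assay can report. Among the three compounds, compound 3 therefore stands at the weak end of what has been seen.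

Compound 4 `O=C(Nc1ccc(C(F)(F)F)cc1)c1csc(Nc2ccccc2Cl)n1` is an unmeasured analogue that differs from compound 3 in a single place: hydrogen in place of trifluoromethyl on an aromatic carbon. Among the measured compounds shown here, the only measured step concerns the exchange of 2,6-dichlorobenzyl for 2,6-dichlorophenoxy and says nothing about a trifluoromethyl on the other ring, so it does not bear on this change. With compound 3 sitting at a limit, no direction can be drawn from the data, and the expectation is simply that compound 4 stays in the weak region, with an expected step of an at least 1.1-fold lower number from compound 3 to compound 4 (0.05 log units; that floor lies within the scatter). Compound 4 is therefore estimated at 3500 nM in this assay, with a range from 800 nM to 15000 nM, and a real chance that only a limit is reported.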

Compound 4, half-maximal inhibitory concentration: 1410 nM
Compound 4: middle estimate off by 2.5-fold (0.39 log units), on the high side, within the range that was stated.
By their numbers in this assay, from the lowest: compound 1; then compounds 2 and 4 (each within the scatter of the next). At a limit, above all of these: compound 3.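

In this assay, hydrogen in place of trifluoromethyl on this aromatic carbon gives an at least 2.8-fold lower number from compound 3 to compound 4 (0.45 log units; beyond the scatter), which shows that the group at this place on the ring matters for the read-out. That step is only a floor, because compound 3 stands at a limit and not at a number: the limit of > 4000 nM in this assay, at which 1 of the 4 values shown sits. With a number now in hand for the (2-chlorophenyl)amino group, its exchange for 2,6-dichlorophenoxy gives a 1.1-fold higher number from compound 2 to compound 4 (0.04 log units; within the scatter), so no difference can be read there, whereas its exchange for 2,6-dichlorobenzyl gives a 16-fold higher number from compound 1 to compound 4 (1.20 log units; beyond the scatter), a large loss that compound 4 does not close.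

The compounds shown leave open what a methyl, a methoxy or a second chloro would give at the carbon where the trifluoromethyl stood, and so whether hydrogen is the best choice there or merely better than trifluoromethyl. Also open, going by these compounds, is whether the remaining chloro of compound 4 contributes at all, a question that a plain phenylamino group on the same core would answer.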